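This account rests on a few compounds, and the source may have more. Where it says the series, first, only, none or still open, it means among the compounds named here.

Measured compounds in a functional assay on OVCAR-3 cells (Homo sapiens) for inhibition, read by sulforhodamine B assay, with a stated time of 48 h; a higher number here means a weaker inhibitor of growth, a lower number a stronger inhibitor of growth:
- compound 1, `COc1ccc(/C=C/C2CC(=O)C=CO2)cc1OC`, gives 74.3 uM
- compound 2, `COc1cc(/C=C/C2CC(=O)C=CO2)cc(OC)c1OC`, gives 85.4 uM
- compound 3, `COc1ccc(/C=C/C2CC=CC(=O)O2)cc1`, gives 61.5 uM

The three values sit close together, and none of the gaps between them is beyond the usual scatter. Compound 1 and compound 2 share a core and differ in one place: methoxy in place of hydrogen on an aromatic carbon. That change gave a 1.1-fold higher number from compound 1 to compound 2 (0.06 log units; within the scatter), a step that is within the scatter and so shows no real effect.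

Compound 4, `COc1ccc(/C=C/C2CC=CC(=O)O2)c(OC)c1`, has not yet been measured. It is built from compound 3 by methoxy in place of hydrogen on an aromatic carbon. The surroundings of the new group are not the same as in compound 2: in compound 2 the methoxy sits ortho to a methoxy group, meta to a group of 9 heavy atoms and meta to a methoxy group, whereas in compound 4 it sits ortho to a group of 9 heavy atoms and meta to a methoxy group. It is therefore the same kind of change, not the same one, and the difference between the two cores is not broken down here.

In this assay the step from compound 3 to compound 4 is expected to be small, a 1.1-fold higher number from compound 3 to compound 4 (0.03 log units; within the scatter), because the matching change gave only a 1.1-fold higher number from compound 1 to compound 2 (0.06 log units; within the scatter). Compound 4 is therefore estimated at 66 uM, most likely between 30 uM and 145 uM.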

Compound 4, concentration for growth inhibition (reported as GI): 5.6 uM
Compound 4: middle estimate off by 12-fold (1.07 log units), on the high side, outside the stated range (below it).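

In this assay, methoxy in place of hydrogen on an aromatic carbon gave an 11-fold lower number from compound 3 to compound 4 (1.04 log units; beyond the scatter), a large step towards stronger growth inhibition on the core of compound 3, with the new group ortho to a group of 9 heavy atoms and meta to a methoxy group. The same kind of change therefore did not carry over from one core to the other in this series: the same change on two cores in this assay, a 1.1-fold higher number (0.06 log units; within the scatter) from compound 1 to compound 2 and an 11-fold lower number (1.04 log units; beyond the scatter) from compound 3 to compound 4, 13-fold (1.10 log units) apart, beyond the scatter of two such steps

What this does not show is which difference sets the two steps apart, the core or the place of the new methoxy, as the two vary together in these compounds.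

The compounds shown leave open whether the large step belongs to methoxy itself or would also appear with a hydroxy group, an ethoxy group or a chlorine atom in the same place. They also leave open what a methoxy ortho to a group of 9 heavy atoms would do on the core of compound 1.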